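Three aryl variants and an untested benzodioxinyl analogue

The compounds below may be only part of what the source reports. "The series", "measured", "known", "first", "only" and "open" are said of these compounds alone.

Of the compounds shown here, three sharing one core have been measured in a functional assay on BE(2)-C cells (Homo sapiens) for inhibition, read by MTT assay, with a stated time of 72 h; a lower number here means a stronger inhibitor of growth, a higher number a weaker inhibitor of growth. Compound 1 `CC(C)(C)c1ccc(CNCCCNS(=O)(=O)c2cc(C(F)(F)F)cc(C(F)(F)F)c2)cc1` gives 2500 nM in this assay. Compound 2 `O=S(=O)(NCCCNCc1ccc(Cl)c(Cl)c1)c1cc(C(F)(F)F)cc(C(F)(F)F)c1` gives 2900 nM in this assay. Compound 3 `COc1ccc(CNCCCNS(=O)(=O)c2cc(C(F)(F)F)cc(C(F)(F)F)c2)cc1OC` gives 3600 nM in this assay, the highest of the three numbers, although its nearest neighbour is compound 2 at a 1.2-fold higher number from compound 2 to compound 3 (0.09 log units; within the scatter) and its furthest is compound 1 at a 1.4-fold higher number from compound 1 to compound 3 (0.16 log units; within the scatter), so nothing separates compound 3 from the others beyond the scatter.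

Compound 4 `O=S(=O)(NCCCNCC1COc2ccccc2O1)c1cc(C(F)(F)F)cc(C(F)(F)F)c1` has not yet been measured in this assay. It differs from compound 3 by 2,3-dihydro-1,4-benzodioxin-2-yl in place of 3,4-dimethoxyphenyl on a saturated chain carbon bound to an amine nitrogen; cut one bond further out, the same change reads 3,4-dimethoxybenzyl to (2,3-dihydro-1,4-benzodioxin-2-yl)methyl.

For the measured compounds named here, the steps that bear on this change are the three swaps of the group on that same saturated chain carbon: a 1.2-fold higher number from compound 1 to compound 2 (0.06 log units; within the scatter), a 1.4-fold higher number from compound 1 to compound 3 (0.16 log units; within the scatter) and a 1.2-fold higher number from compound 2 to compound 3 (0.09 log units; within the scatter). All three lie within the scatter, so the measured data give no sign that this position governs the number in this assay, and no step beyond the scatter is expected for compound 4 in this assay. The estimated step is no change at the digits printed from compound 3 to compound 4 (within the scatter). Compound 4 is therefore expected to give about 3600 nM in this assay, within a range from 1500 nM to 9000 nM.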

Compound 4, concentration for 50% growth inhibition: 2800 nM
For compound 4 the middle estimate is 1.3-fold (0.11 log units) above the measured one; the range from low to high includes it.
By their numbers in this assay, from the lowest: compounds 1, 4, 2 and 3 (each within the scatter of the next).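

The three earlier compounds varied only substituted phenyl groups on this saturated chain carbon, whereas 2,3-dihydro-1,4-benzodioxin-2-yl brings an added six-membered non-aromatic ring with 2 hetero atoms to the same place. Even so, the number in this assay stays within the scatter of all three earlier compounds, with a 1.3-fold lower number from compound 3 to compound 4 (0.11 log units; within the scatter), a 1.0-fold lower number from compound 2 to compound 4 (0.02 log units; within the scatter) and a 1.1-fold higher number from compound 1 to compound 4 (0.05 log units; within the scatter). The insensitivity seen among the phenyl groups therefore now extends to a group with a different ring make-up, though no measurement available here accounts for this flat result.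

The compounds shown leave open whether a group of another kind at this place, such as a carboxylic acid, a primary amine or a lone methyl, would take the number beyond the scatter. All four compounds also keep the rest of the shared core the same, so what a longer chain, or a nitrile in place of either trifluoromethyl, would do to the number in this assay remains an open question.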